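Cyclohexyl Removed: Expected Effect on Antiproliferative Potency

A few compounds are considered here, and "the series" means these few. Any claim that something is new, unique, unknown or untested is made for them only; others in the source may bear on it.

Three compounds share one core and differ only in the group on the saturated chain carbon bound to the aromatic nitrogen. In a functional assay on MCF7 cells (Homo sapiens) for antiproliferative activity (on this read-out higher numbers stand for weaker inhibition and lower numbers for stronger inhibition), compound 1 `C=CCCCn1c(Cc2cc(OC)c(OC)c(OC)c2)nc2c(N)nc(F)nc21` gives 44700 nM, compound 3 `CC#CCCn1c(Cc2cc(OC)c(OC)c(OC)c2)nc2c(N)nc(F)nc21` gives 37200 nM, and compound 2 `COc1cc(Cc2nc3c(N)ncnc3n2CC2CCCCC2)cc(OC)c1OC` gives 39800 nM. Compound 2 stands second highest of the three numbers, but its gaps to compound 3 and to compound 1 both lie within the scatter, so the three cannot be told apart on this assay. Among the compounds with values here, the one measured step, a 1.2-fold lower number from compound 1 to compound 3 (0.08 log units; within the scatter), is likewise within the scatter. Compound 4 `COc1cc(Cc2nc3c(N)ncnc3n2C)cc(OC)c1OC` differs from compound 2 by hydrogen in place of cyclohexyl on a saturated chain carbon bound to an aromatic nitrogen. Within the data shown here, no measured step touches this change; the only step available concerns a group two bonds along the chain from an aromatic nitrogen and did not move the number. Because compound 2 gives 39800 nM and nothing in the series has shifted the read-out, compound 4 is expected to stay close to it, with an expected step of a 1.3-fold higher number from compound 2 to compound 4 (0.10 log units; within the scatter). Compound 4 is estimated at 50000 nM, ranging from 15000 nM to 160000 nM.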

Compound 4, half-maximal inhibitory concentration: 70800 nM
Beside the measured number, compound 4's estimate is 1.4-fold (0.15 log units) below it; low and high end bracket the measured number.
By their numbers in this assay, from the lowest: compounds 3, 2, 1 and 4 (each within the scatter of the next).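

Within the data shown here, the change from cyclohexyl to hydrogen, on a saturated chain carbon bound to an aromatic nitrogen, gives the first measured step at this place, and in this assay it reads a 1.8-fold higher number from compound 2 to compound 4 (0.25 log units; within the scatter). The earlier step concerned a small change further along the chain, whereas this one takes away a whole six-membered non-aromatic ring of carbon only, cutting cyclohexylmethyl back to methyl, and the number still cannot be told from the scatter. Even this large loss of carbon therefore leaves no readable change in this series, and nothing available explains that result. The compounds shown leave open whether a group at this place that carries an amine or a carboxylic acid would move the number beyond the scatter. From the compounds shown here alone, a longer chain ending in a phenyl ring remains equally open.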